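This account rests on a few compounds, and the source may have more. Where it says the series, first, only, none or still open, it means among the compounds named here.

Measured in a physicochemical assay for solubility, at pH 7.4; a higher number here means a more soluble compound, a lower number a less soluble compound:
- compound 1 `CCc1ccc(NC(=O)Nc2cc(C)nc3ccccc23)cc1` gives 3300 nM
- compound 2 `Cc1cc(NC(=O)Nc2ccc(C(N)=O)cc2)c2ccccc2n1` gives 900 nM
- compound 3 `Cc1cc(NC(=O)Nc2ccc(O)cc2)c2ccccc2n1` gives 100 nM

Compound 3 holds the lowest number of the three, and both other compounds lie above it beyond the scatter. The unmeasured compound 4 `Cc1cc(NC(=O)Nc2ccc(Cl)cc2)c2ccccc2n1` has chloro in place of hydroxy on an aromatic carbon, para to a large group (chloro in place of hydroxy on an aromatic carbon). Within the data shown here, no chloro compound has been measured, so the nearest guidance comes from the two steps that bring in hydroxy. The large one is a 33-fold lower number from compound 1 to compound 3 (1.52 log units; beyond the scatter) and the modest one is a 9.0-fold lower number from compound 2 to compound 3 (0.95 log units; beyond the scatter). Both lead to a lower number, so losing hydroxy is expected to give a higher number in this assay, by a modest to large step. The expected step is a 12-fold higher number from compound 3 to compound 4 (1.08 log units; beyond the scatter). For compound 4 the estimated value is 1200 nM, with an expected range of 300 nM to 4000 nM.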

Compound 4, solubility: 1400 nM
For compound 4 the middle estimate is 1.2-fold (0.07 log units) below the measured one, within the range that was stated.
By their numbers in this assay, from the lowest: compound 3; then compounds 2 and 4 (each within the scatter of the next); then compound 1.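

In this assay, the change from 4-hydroxyphenyl to 4-chlorophenyl gives a 14-fold higher number from compound 3 to compound 4 (1.15 log units; beyond the scatter), so compound 3 stays low against a third group at this position, not only against ethyl and carbamoyl. Chloro and carbamoyl cannot be told apart here, with a 1.6-fold higher number from compound 2 to compound 4 (0.19 log units; within the scatter), so these two different groups give matching results. Ethyl remains clear of chloro, with a 2.4-fold lower number from compound 1 to compound 4 (0.37 log units; beyond the scatter), and so compound 1 stays highest of the four.

As far as these compounds go, whether an amine or a carboxylic acid at this position would fall near hydroxy or near ethyl remains open. No measurement shown offers an explanation for these steps.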